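A few compounds are considered here, and "the series" means these few. Any claim that something is new, unique, unknown or untested is made for them only; others in the source may bear on it.

In a functional assay on HT-29 cells (Homo sapiens) for inhibition, read by MTT assay, with a stated time of 72 h (a higher number here means a weaker inhibitor, a lower number a stronger inhibitor), compound 1 (`CN(C)CCn1c(=O)c(=Cc2ccc(O)cc2)s/c1=C1\C(=O)Nc2ccc(Cl)cc21`) gives 2460 nM and compound 2 (`COc1ccc(OC)c(C=c2s/c(=C3\C(=O)Nc4cc(F)ccc43)n(CCN(C)C)c2=O)c1`) gives 4450 nM there, a pair within the usual scatter of each other. Compound 3 (`CN(C)CCn1c(=O)c(=Cc2ccc(O)cc2)s/c1=C1\C(=O)Nc2ccc(Br)cc21`) carries bromo in place of chloro on an aromatic carbon of the core of compound 1. The series holds no measured exchange of this kind, so the expectation rests on compound 1 at 2460 nM alone, with no shift beyond the scatter expected. The estimated step of a 1.0-fold lower number from compound 1 to compound 3 (0.01 log units; within the scatter) is expected to stay within the scatter. Compound 3 is estimated at 2400 nM in this series, with 1100 nM to 5000 nM as the expected range.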

Compound 3, half-maximal inhibitory concentration: 1920 nM
Estimate against measurement, compound 3: 1.3-fold (0.10 log units) above; the range from low to high includes it.
By their numbers in this assay, from the lowest: compounds 3, 1 and 2 (each within the scatter of the next, the first and the last beyond it).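

In this assay, the exchange of chloro for bromo on this aromatic carbon of the shared core, with everything else held fixed, is a 1.3-fold lower number from compound 1 to compound 3 (0.11 log units; within the scatter). Going by these compounds alone, this is the first single-place comparison, and at this position the two halogens cannot be told apart. No data bearing on a cause accompany this step.

Going by these compounds, whether a group of another kind here, such as methoxy, an amine or a carboxylic acid, would move the number beyond the scatter remains open. So does the reach of this result to other positions on the same ring.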